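Second ring fluoro on the benzyl arm of compound 2

This account rests on a few compounds, and the source may have more. Where it says the series, first, only, none or still open, it means among the compounds named here.

Compound 1 `CC1(C)c2[nH]nc(NC(=O)c3ccccc3)c2CN1Cc1cccc(Cl)c1` gives 670 nM in an assay on Sf21 cells for inhibition of high affinity nerve growth factor receptor (Homo sapiens), read by HTRF, with a stated time of 30 min, in the presence of a further agent that is not named here; on this read-out higher numbers stand for weaker inhibition and lower numbers for stronger inhibition. Compound 2 `CC1(C)c2[nH]nc(NC(=O)c3ccccc3)c2CN1Cc1ccc(F)cc1` gives 1180 nM in this assay. For the measured compounds named here, the single step between them, a 1.8-fold higher number from compound 1 to compound 2 (0.25 log units; within the scatter), exchanges 3-chlorophenyl for 4-fluorophenyl on the saturated chain carbon bound to the ring amine nitrogen. Going by the values given here, compound 2 therefore sits within the scatter of compound 1, its only neighbour; of the two numbers, neither separates from the other.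

Compound 3 `CC1(C)c2[nH]nc(NC(=O)c3ccccc3)c2CN1Cc1ccc(F)cc1F` carries fluoro in place of hydrogen on an aromatic carbon, ortho to a large group and meta to the fluoro already present, so that 4-fluorobenzyl becomes 2,4-difluorobenzyl. Among the compounds with values here, no measured step adds a second fluoro to this ring; the one available step, a 1.8-fold higher number from compound 1 to compound 2 (0.25 log units; within the scatter), changed the halogen and its position on the same ring without leaving the scatter. The expected step, a 1.1-fold lower number from compound 2 to compound 3 (0.03 log units; within the scatter), is accordingly none beyond the scatter. Compound 3 is estimated at 1100 nM in this assay, within a range from 450 nM to 2700 nM.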

Compound 3, half-maximal inhibitory concentration: 2320 nM
For compound 3 the middle estimate is 2.1-fold (0.32 log units) below the measured one; measured number inside the range.
By their numbers in this assay, from the lowest: compounds 1, 2 and 3 (each within the scatter of the next, the first and the last beyond it).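

In this assay, fluoro in place of hydrogen on the aromatic carbon ortho to a large group gives a 2.0-fold higher number from compound 2 to compound 3 (0.29 log units; within the scatter) and so does not by itself separate compound 3 from compound 2. Set against the 3-chlorophenyl arm, however, the 2,4-difluorophenyl arm gives a 3.5-fold higher number from compound 1 to compound 3 (0.54 log units; beyond the scatter) and this is the first step in the series to leave the scatter, so changes on this aromatic ring alone can produce a modest separation, here towards weaker inhibition. Nothing on hand bears on why either step has this size.

Open, from the compounds shown here alone, is whether a methoxy or an amine at this same place would stay within the scatter of compound 2. Also open, going by these compounds, is whether 2-fluorophenyl or 2,4-dichlorophenyl would sit nearer compound 1 or compound 3.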